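The source may report more compounds than this note shows. Statements on the series, on what has been measured and on what is new or still open speak of the compounds shown alone.

The measured compounds:
compound 1, `O=C(O)CC(Cc1nc2cc(F)ccc2[nH]1)c1ccc(Cl)cc1`; in an assay on isolated protein for inhibition of protein kinase C zeta type (Homo sapiens), read by 33P incorporation, tested at 200 uM (a higher number here means a stronger effect of the compound at the concentration tested, a lower number a weaker effect), compound 1 gives 30%.
compound 2, `O=C(O)CC(Cc1nc2cc(Br)ccc2[nH]1)c1ccc(Cl)cc1`; compound 2 gives 80%.
compound 3, `O=C(O)CC(Cc1nc2cc(C(F)(F)F)ccc2[nH]1)c1ccc(Cl)cc1`; compound 3 gives 85%.

Compound 3 stands highest of the three numbers, but its nearest neighbour, compound 2, lies within the scatter of it: a number 5 percentage points higher from compound 2 to compound 3 (within the scatter). Only against compound 1 is the gap large: a number 55 percentage points higher from compound 1 to compound 3 (beyond the scatter), and the same is seen for a number 50 percentage points higher from compound 1 to compound 2 (beyond the scatter).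

Compound 4, `O=C(O)CC(Cc1nc2cc(C(=O)O)ccc2[nH]1)c1ccc(Cl)cc1`, differs from compound 3 at one place: carboxy in place of trifluoromethyl on an aromatic carbon. All three measured steps exchange a group at this same aromatic carbon of the shared core. Fluoro to bromo and fluoro to trifluoromethyl each raised the number strongly, while bromo to trifluoromethyl left it within the scatter. Among the measured compounds shown here, none of the measured steps introduces a carboxy group, which brings a hydrogen-bond donor and a hydrogen-bond acceptor where trifluoromethyl has none, and the measured steps give no direct guide for such an exchange. The direction of the step is not fixed by the numbers shown. A cautious downward step is therefore expected: a number 40 percentage points lower from compound 3 to compound 4 (beyond the scatter). Compound 4 is thus estimated at 45% in this assay, between 15% and 80%.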

Compound 4, a percentage reported as inhibition, at one concentration (the size of the read-out at that concentration, not a potency): 0%
Estimate against measurement, compound 4: 45 percentage points above; measured number below the stated range.
By their numbers in this assay, from the lowest: compound 4; then compound 1; then compounds 2 and 3 (each within the scatter of the next).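

At this aromatic carbon, carboxy is the first group shown to lower the number in this assay, and it does so against each of the other three groups: a number 85 percentage points lower from compound 3 to compound 4 (beyond the scatter), a number 80 percentage points lower from compound 2 to compound 4 (beyond the scatter), and a number 30 percentage points lower from compound 1 to compound 4 (beyond the scatter). The earlier compounds shown here separated only fluoro from the level pair of bromo and trifluoromethyl, whereas with the exchange of a single group here compound 4 gives 0%, and even fluoro, the lowest of the earlier groups, stands clearly above carboxy. Nothing in the available data accounts for this drop.

The compounds shown leave open whether the loss belongs to the carboxy group alone or would also appear with its methyl ester, a primary amide, a nitrile or an amine on this aromatic carbon. They also leave open whether carboxy would give a step of the same size if the carboxylic acid on the chain of the shared core were replaced by its methyl ester.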